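Thiophen-2-yl in Place of Iodo on the Shared Core

The compounds below may be only part of what the source reports. "The series", "measured", "known", "first", "only" and "open" are said of these compounds alone.

Compound 3 `Cc1cc(I)c2ncc(CSCCc3ccccc3)n2c1` carries an iodo group on its core. In an ADME assay on HEL cells (Homo sapiens) for cytotoxicity, with a stated time of 3 days (a lower number here means that less compound is tolerated, a higher number that more compound is tolerated), compound 3 gives only a limit, > 50 ug/mL. Compound 2 `Cc1cc(-c2ccsc2)c2ncc(CSCCc3ccccc3)n2c1` likewise gives only a limit in this assay, > 50 ug/mL. Compound 1 `Cc1cc(-c2ccc(O)cc2)c2ncc(CSCCc3ccccc3)n2c1` gives 13.7 ug/mL in this assay. Two of the three values therefore share the same limit, (the limit of > 50 ug/mL in this assay, at which 2 of the 3 values shown sit). The step of an at least 3.6-fold higher number from compound 1 to compound 3 (0.56 log units; beyond the scatter) and the step of an at least 3.6-fold higher number from compound 1 to compound 2 (0.56 log units; beyond the scatter) both lead from a numbered value to a limit; the step that the two limits leave unreadable from compound 2 to compound 3 cannot be read, because both ends are limits.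

Compound 4 `Cc1cc(-c2cccs2)c2ncc(CSCCc3ccccc3)n2c1` differs from compound 3 by thiophen-2-yl in place of iodo on an aromatic carbon. Within the data shown here, the step that bears most closely on it is an at least 3.6-fold higher number from compound 1 to compound 2 (0.56 log units; beyond the scatter), where a related thiophene also sits at the limit; what separates compound 2 from compound 4 has no measured counterpart here. Compound 4 is therefore expected to remain at or near the limit, with an estimated step that the limit leaves unreadable from compound 3 to compound 4 that cannot be distinguished from none. Compound 4 is estimated at 60 ug/mL, within 30 ug/mL to 120 ug/mL, in this assay.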

Compound 4, half-maximal cytotoxic concentration: > 50 ug/mL
Compound 4 ended at the assay's limit; the forecaster's own chance of this, stated with the estimate: 70%; the middle value is on the limit's open side.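

Among these compounds, with thiophen-2-yl on this aromatic carbon, the read-out in this assay stays at the same limit as with iodo and thiophen-3-yl, so 4-hydroxyphenyl remains the only group here with a numbered value: the limit of > 50 ug/mL in this assay, at which 3 of the 4 values shown sit. Thiophen-2-yl in place of 4-hydroxyphenyl gives an at least 3.6-fold higher number from compound 1 to compound 4 (0.56 log units; beyond the scatter), so both thiophene attachments now stand apart from compound 1 beyond the scatter. The steps from compound 3 to compound 4 and from compound 2 to compound 4 cannot be read, as both ends of each are limits.

The compounds shown leave open how far past the limit compound 2, compound 3 and compound 4 lie. They also leave open whether a plain phenyl or a 4-aminophenyl group at this position would give a numbered value like compound 1 or stay at the limit.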